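A Bromo Addition Tested Against an Assay Ceiling

A few compounds are considered here, and "the series" means these few. Any claim that something is new, unique, unknown or untested is made for them only; others in the source may bear on it.

Compound 1 `COc1c(Br)cccc1C(=O)Nc1ccc(Sc2nc3ccccc3s2)c(Cl)c1`: > 100000 nM in an assay for inhibition of HSP60/HSP10 (Homo sapiens), with a stated time of 60 min; a higher number here means a weaker inhibitor, a lower number a stronger inhibitor
Compound 2 `COc1ccccc1C(=O)Nc1ccc(Sc2nc3ccccc3s2)cc1`: > 100000 nM in this assay

The value of compound 2 in this assay is a limit of the assay, not a number. The value of compound 1 is likewise a limit. Compound 3 `COc1c(Br)cccc1C(=O)Nc1ccc(Sc2nc3ccccc3s2)cc1` differs from compound 2 by bromo in place of hydrogen on an aromatic carbon. Going by the values given here, no step between measured compounds is available, and because the limit of > 100000 nM in this assay, at which 2 of the 2 values shown sit, no change beyond the scatter is expected here. Compound 3 is expected to give 150000 nM, between 30000 nM and 1000000 nM. The expected step that the limit leaves unreadable from compound 2 to compound 3 is estimated to stay within the scatter.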

Compound 3, half-maximal inhibitory concentration: > 100000 nM
Compound 3 ended at the assay's limit (the forecaster's own chance of this, stated with the estimate: 85%); the middle value is on the limit's open side.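

No step from compound 2 or compound 1 to compound 3 can be read, since all three values in this assay are limits: the limit of > 100000 nM in this assay, at which 3 of the 3 values shown sit.

The compounds shown leave open whether bromo or chloro on the shared core changes inhibition at all.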